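The source may hold more compounds than are shown below. What is called first, only, known or untested is meant among the compounds shown, and "the series" means these compounds.

Working notes on the series. In a functional assay on Jurkat cells (Homo sapiens) (on this read-out lower numbers stand for stronger inhibition and higher numbers for weaker inhibition), compound 1 `CC(C)[C@H](NC(=O)COc1cccc2ccccc12)C(=O)N[C@@H](CC(=O)O)C(=O)COc1ccccc1C(F)(F)F` is reported only as a limit, > 100000 nM. Among the measured compounds shown here, compound 2 `CC(C)[C@H](NC(=O)COc1cccc2ccccc12)C(=O)N[C@@H](CC(=O)O)C(=O)COc1cc(F)c(F)cc1F` gives 39300 nM, the only actual number so far, which leaves it with no second number for comparison. The change to compound 3 `CC(C)[C@H](NC(=O)COc1cccc2ccccc12)C(=O)N[C@@H](CC(=O)O)C(=O)COc1c(F)cc(F)cc1F` is 2,4,6-trifluorophenyl in place of 2,4,5-trifluorophenyl on an oxygen on a saturated carbon, with 2,4,6-trifluorophenyl in place of 2,4,5-trifluorophenyl on the same oxygen. For the measured compounds named here, one measured step bears on it: an at least 2.5-fold lower number from compound 1 to compound 2 (0.40 log units; beyond the scatter). That step is a change at the same place, but it replaces a 2-(trifluoromethyl)phenyl group and so offers only loose guidance for a rearrangement of the same atoms. Going by these compounds, its true size also stays open, as it starts from the limit of > 100000 nM in this assay, at which 1 of the 2 values shown sits. No change beyond the scatter is therefore expected in this assay, with either direction possible. The expected size is a 1.1-fold lower number from compound 2 to compound 3 (0.05 log units; within the scatter). For compound 3, the estimate is 35000 nM, with an expected range of 10000 nM to 100000 nM.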

Compound 3, half-maximal inhibitory concentration: 6840 nM
Compound 3: middle estimate off by 5.1-fold (0.71 log units), on the high side, outside the stated range (below it).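

In this assay, this position on the oxygen proves sensitive to the arrangement of the three fluorines alone: with the same atoms and the same counts, moving to 2,4,6-trifluorophenyl gives a 5.7-fold lower number from compound 2 to compound 3 (0.76 log units; beyond the scatter). Measured against 2-(trifluoromethyl)phenyl on the same oxygen, the 2,4,6-trifluorophenyl group gives an at least 14-fold lower number from compound 1 to compound 3 (1.16 log units; beyond the scatter). Compound 1 is held only as a limit, so the true size of that longer step stays open: the limit of > 100000 nM in this assay, at which 1 of the 3 values shown sits.

The compounds shown leave open whether 2,6-difluorophenyl or 2,4,6-trichlorophenyl on the same oxygen would hold or improve on the level of compound 3. Also open, going by these compounds, is whether the difference between the two trifluorophenyl groups persists when a primary amide stands in place of the carboxylic acid of the shared core.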